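Swapping a Piperidine for a Benzyl on the Core

This account rests on a few compounds, and the source may have more. Where it says the series, first, only, none or still open, it means among the compounds named here.

Compound 1 `NS(=O)(=O)Oc1ccc2c(c1)CN(C(=O)c1ccc(N3CCC(N4CCCCC4)CC3)cc1)CC2` is one of three compounds tested in an assay on HEK293 cells for inhibition of Steryl-sulfatase (Homo sapiens), tested at 1 uM (on this read-out lower numbers stand for a weaker effect and higher numbers for a stronger effect at the one concentration tested), where compound 1 gives 53.7%. That number stands second highest of the three. Compound 2 `CCN(Cc1ccc(F)cc1)c1ccc(C(=O)N2CCc3ccc(OS(N)(=O)=O)cc3C2)cc1` gives 91.2% in this assay, higher by more than the usual scatter, while compound 3 `CN(CCCN1CCCCC1)c1cccc(C(=O)N2CCc3ccc(OS(N)(=O)=O)cc3C2)c1` gives 30.6% in this assay, lower by more than the scatter. Compound 4 `NS(=O)(=O)Oc1ccc2c(c1)CN(C(=O)c1ccc(N3CCC(Cc4ccccc4)CC3)cc1)CC2` has not yet been measured. It differs from compound 1 in one place: benzyl in place of piperidin-1-yl on a saturated ring carbon. Within the data shown here, no measured pair shows this same change, so the size of the step is uncertain; a moderate rise is expected, partly because compound 2 gives 91.2% in this assay. The step from compound 1 to compound 4 is expected to be a number 11.3 percentage points higher from compound 1 to compound 4 (beyond the scatter). Compound 4 is estimated at 65%, within 40% to 88%.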

Compound 4, a percentage reported as inhibition, at one concentration (the size of the read-out at that concentration, not a potency): 81.3%
Compound 4: the middle estimate sits 16.3 percentage points below what was measured; low and high end bracket the measured number.
By their numbers in this assay, from the lowest: compound 3; then compound 1; then compounds 4 and 2 (each within the scatter of the next).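

Putting benzyl in place of piperidin-1-yl on this saturated ring carbon gives a number 27.6 percentage points higher from compound 1 to compound 4 (beyond the scatter) in this assay. At this position, then, the effect does not depend on the ring nitrogen of piperidin-1-yl, and a ring of carbon only can take its place. Nothing available explains why the number rises. The compounds shown leave open whether the aromatic ring or the absence of that nitrogen matters more; a cyclohexyl group on the same carbon would help separate the two.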